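A few compounds are considered here, and "the series" means these few. Any claim that something is new, unique, unknown or untested is made for them only; others in the source may bear on it.

Compound 1, `Cc1ccc(S(=O)(=O)N2CC=C(Cl)CC2)cc1`, in a functional assay on SW1573 cells (Homo sapiens) for antiproliferative activity, read by sulforhodamine B assay, with a stated time of 48 h (on this read-out lower numbers stand for stronger inhibition of growth and higher numbers for weaker inhibition of growth), gives > 100000 nM, which is a limit of the assay and not a number.
Compound 2, `Cc1ccc(S(=O)(=O)N2CCC(Cl)=CC2CC(C)C)cc1`, in this assay gives 31000 nM.
Compound 3, `CCCCCCCC1C=C(Cl)CCN1S(=O)(=O)c1ccc(C)cc1`, in this assay gives 49000 nM.

Going by the values given here, compound 1 therefore stands at the edge of what this assay can report: it is the one compound among the three that gives only a limit, (the limit of > 100000 nM in this assay, at which 1 of the 3 values shown sits). The two steps away from it both add a chain to a saturated ring carbon of the shared core: an at least 3.2-fold lower number from compound 1 to compound 2 (0.50 log units; beyond the scatter), and an at least 2.0-fold lower number from compound 1 to compound 3 (0.30 log units; that floor lies within the scatter). Between those two chains the change is small, a 1.6-fold higher number from compound 2 to compound 3 (0.20 log units; within the scatter).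

Compound 4, `Cc1ccc(S(=O)(=O)N2CC=C(Br)CC2)cc1`, differs from compound 1 in another part of the core: bromo in place of chloro on a double-bonded ring carbon. None of the measured steps touches that double-bonded ring carbon or exchanges one halogen for another, so none of them bears directly on this change, and the numbers give no reason to expect a step beyond the scatter in this assay in either direction. The expected step is a step that the limit leaves unreadable from compound 1 to compound 4. Compound 4 is therefore estimated at 120000 nM in this assay, with a range from 50000 nM to 300000 nM, and it is quite likely that the assay will again report only a limit for compound 4.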

Compound 4, concentration for 50% growth inhibition: > 100000 nM
Compound 4 was reported as a limit; the forecaster's own chance of this, stated with the estimate: 65%; the middle value lies beyond the limit too.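

In this assay compound 4 gives > 100000 nM, which is a limit of the assay and not a number. Going by these compounds alone, compound 1 also gives only a limit, so no step from it to compound 4 can be read: the limit of > 100000 nM in this assay, at which 2 of the 4 values shown sit. The compounds shown leave open whether bromo in place of chloro on a double-bonded ring carbon changes growth inhibition in either direction.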